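Sulfamoyl in place of phenyl on compound 1

The compounds below may be only part of what the source reports. "The series", "measured", "known", "first", "only" and "open" are said of these compounds alone.

Compound 1 `O=C1C(Nc2ccc(-c3ccccc3)cc2)=CC(=O)c2ncncc21` gives 500 nM
Compound 2 `COc1cc(NC2=CC(=O)c3ncncc3C2=O)cc(OC)c1OC` gives 1600 nM

In a functional assay on BXPC-3 cells (Homo sapiens) for cytotoxicity, read by MTT assay, with a stated time of 72 h (a higher number here means a weaker inhibitor, a lower number a stronger inhibitor), compound 1 has the lower of the two numbers, at 500 nM, and the gap to compound 2 lies beyond the scatter. Compound 3 `NS(=O)(=O)c1ccc(NC2=CC(=O)c3ncncc3C2=O)cc1` carries sulfamoyl in place of phenyl on an aromatic carbon. Among the compounds with values here, no measured pair differs in one place, so this change has not been tested on its own. Compound 2, which also lacks the phenyl, gives 1600 nM, so a rise beyond the scatter is expected, towards a weaker inhibitor. The estimated step is a 4.0-fold higher number from compound 1 to compound 3 (0.60 log units; beyond the scatter). Compound 3 is expected at 2000 nM, within an estimated range of 700 nM to 6000 nM.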

Compound 3, half-maximal inhibitory concentration: > 10000 nM
Compound 3: only a limit was reported (the forecaster's own chance of this, stated with the estimate: 5%); middle value at least 5.0-fold (0.69 log units) away from the limit.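

In this assay compound 3 gives > 10000 nM, which is a limit of the assay and not a number. Sulfamoyl in place of phenyl on an aromatic carbon, para to a large group, is the first change here that can be read on its own, a step of an at least 20-fold higher number from compound 1 to compound 3 (1.30 log units; beyond the scatter). This position therefore does not tolerate every replacement of the phenyl, and the full size of the loss cannot be read: the limit of > 10000 nM in this assay, at which 1 of the 3 values shown sits.

The compounds shown leave open how an amine, a carboxylic acid or a methyl group would read on this aromatic carbon. They also leave open whether another ring, such as pyridine, could stand in for the phenyl.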